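Working notes: from compound 3 to compound 4

The source may hold more compounds than are shown below. What is called first, only, known or untested is meant among the compounds shown, and "the series" means these compounds.

In a functional assay on DLD-1 cells (Homo sapiens) for cytotoxicity, with a stated time of 48 h (on this read-out lower numbers stand for stronger inhibition and higher numbers for weaker inhibition), compound 1 `CCCC(=O)Oc1ccc2oc(/C=C/[S+](C)[O-])cc(=O)c2c1` gives 8700 nM, compound 2 `CCC(=O)Oc1ccc2oc(/C=C/[S+](C)[O-])cc(=O)c2c1` gives 9000 nM and compound 3 `CC(C)Oc1ccc2oc(/C=C/[S+](C)[O-])cc(=O)c2c1` gives 8000 nM. Compound 3 thus stands within the scatter of both other compounds, and the three numbers cannot be ranked.

Compound 4 `C[S+]([O-])/C=C/c1cc(=O)c2cc(OC(=O)C(C)(C)C)ccc2o1` carries (tert-butyl)carbonyl in place of isopropyl on an oxygen on an aromatic ring.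

Two measured steps make a similar exchange at this oxygen, isopropyl in place of propylcarbonyl in a 1.1-fold lower number from compound 1 to compound 3 (0.04 log units; within the scatter) and isopropyl in place of propanoyl in a 1.1-fold lower number from compound 2 to compound 3 (0.05 log units; within the scatter). A third step alters only the chain of the carbonyl group, a 1.0-fold higher number from compound 1 to compound 2 (0.01 log units; within the scatter). All three lie within the scatter. Among the measured compounds shown here, no measured compound carries a tert-butyl group, so that feature remains untested.

No step beyond the scatter is therefore expected, and the expected size in this assay is a 1.1-fold higher number from compound 3 to compound 4 (0.03 log units; within the scatter). The estimate for compound 4 is 8500 nM, with an expected range of 4500 nM to 16000 nM.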

Compound 4, half-maximal inhibitory concentration: 8000 nM
Compound 4: middle estimate off by 1.1-fold (0.03 log units), on the high side, and the stated range covers the measured number.
By their numbers in this assay, from the lowest: compounds 3, 4, 1 and 2 (each within the scatter of the next).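

In this assay, the bulkier (tert-butyl)carbonyl group on an oxygen on an aromatic ring leaves the read-out where isopropyl had it (no change at the digits printed from compound 3 to compound 4 (within the scatter)). Among the compounds shown here, the tert-butyl feature, untested in the earlier compounds, also stays within the scatter when set against the unbranched acyl chains: tert-butyl in place of ethyl on a carbonyl carbon (a 1.1-fold lower number from compound 2 to compound 4 (0.05 log units; within the scatter)) and tert-butyl in place of propyl on a carbonyl carbon (a 1.1-fold lower number from compound 1 to compound 4 (0.04 log units; within the scatter)). This position has thus now tolerated branching on the carbonyl group as well as chain length and the exchange of ester for ether with no step beyond the scatter, and nothing at hand accounts for that flatness.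

From the compounds shown here alone, whether a benzoyl group, a much longer chain or a group ending in an amine or a carboxylic acid at this oxygen would separate from these four compounds stays open. All four also share the rest of the structure, so the response to changes elsewhere on the shared core is equally unknown.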